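Hydroxy in Place of Methoxy: From Compound 3 to Compound 4

The compounds below may be only part of what the source reports. "The series", "measured", "known", "first", "only" and "open" are said of these compounds alone.

Measured compounds:
compound 1, `COc1cc(C)cc(-c2nn(CC#N)cc2-c2ccc(-c3cccc(C(C)=O)c3)nc2)c1`, gives 97%
compound 2, `Cc1cc(O)cc(-c2nn(CC#N)cc2-c2ccnc(-c3ccc(Oc4ccccc4)cc3)c2)c1`, gives 95%
compound 3, `COc1cc(C)cc(-c2nn(CC#N)cc2-c2ccnc(-c3ccc(N(C)C)cc3)c2)c1`, gives 96%

All three were tested in a functional assay on 786-0 cells (Homo sapiens) for cytotoxicity, read by sulforhodamine B assay, with a stated time of 48 h, tested at 0.01 uM; on this read-out higher numbers stand for a weaker effect at the one concentration tested and lower numbers for a stronger effect. Compound 1 reads 97%, compound 2 reads 95% and compound 3 reads 96%. On these numbers compound 3 lies between the other two, and its distance to compound 1 as well as to compound 2 is within the usual scatter, so the three compounds cannot be told apart in this assay.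

Compound 4, `Cc1cc(O)cc(-c2nn(CC#N)cc2-c2ccnc(-c3ccc(N(C)C)cc3)c2)c1`, has not yet been measured. It differs from compound 3 in one place: hydrogen in place of methyl on an oxygen on an aromatic ring. The same kind of 3-hydroxy-5-methylphenyl group is already present in compound 2, whose number in this assay sits together with those of compound 1 and compound 3.

Because compound 2 gives 95% and compound 3 gives 96%, no step beyond the scatter is expected in this assay, in either direction. The expected step is no change at the digits printed from compound 3 to compound 4 (within the scatter). For compound 4 the estimate is 96%, with a range from 88% to 102%.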

Compound 4, a percentage reported as activity, at one concentration (the size of the read-out at that concentration, not a potency): 88%
Compound 4: middle estimate off by 8 percentage points, on the high side; measured number inside the range.
By their numbers in this assay, from the lowest: compounds 4, 2, 3 and 1 (each within the scatter of the next).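

Within the data shown here, the change of methoxy to hydroxy on the 3-methoxy-5-methylphenyl group could not be read from the earlier compounds, and in this assay compounds 3 and 4 now isolate it as a number 8 percentage points lower from compound 3 to compound 4 (within the scatter) and so give the first direct reading at this position. With the 3-hydroxy-5-methylphenyl group held in common, dimethylamino in place of phenoxy on an aromatic carbon reads as a number 7 percentage points lower from compound 2 to compound 4 (within the scatter) at the far end of the molecule, so neither change separates from the scatter at the single concentration tested. Nothing in the material at hand accounts for either reading.

The compounds shown leave open whether an ethoxy group, a longer chain on the same oxygen, or an amine in place of the oxygen would give a reading beyond the scatter in this assay. They also leave open whether the methoxy to hydroxy change would read the same way on a compound carrying the phenoxy group or the acetyl-bearing group of the other compounds, and how any of these compounds would read at higher concentrations.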